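Replacing the five-membered ring on the chain of compound 2

The compounds below may be only part of what the source reports. "The series", "measured", "known", "first", "only" and "open" are said of these compounds alone.

Compound 1 `COc1cc(O)c(C(=O)OCC2CCCCC2)c(/C=C/CN2C(=O)C=CC2=O)c1` and compound 2 `COc1cc(O)c(C(=O)OC(C)C)c(/C=C/CN2C(=O)C=CC2=O)c1` share one core and differ only in the ester group. In a functional assay on MV4-11 cells (Homo sapiens) for antiproliferative activity, read by luminescence, with a stated time of 72 h (a higher number here means a weaker inhibitor, a lower number a stronger inhibitor), compound 1 gives 1970 nM, and compound 2 gives 1730 nM. For the measured compounds named here, the single measured step, a 1.1-fold lower number from compound 1 to compound 2 (0.06 log units; within the scatter), shows that the two ester groups are not separated by the data. Compound 2 therefore stands at the lower of the two numbers, though within the scatter of compound 1.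

Compound 3 `COc1cc(O)c(C(=O)OC(C)C)c(/C=C/CNC(C)=O)c1` keeps the ester of compound 2 and alters the chain: a group of 4 heavy atoms (2 carbon, 1 nitrogen, 1 oxygen; no ring) in place of a group of 7 heavy atoms (4 carbon, 1 nitrogen, 2 oxygen; one five-membered non-aromatic ring with 1 hetero atom), on a saturated chain carbon bound to a double-bonded chain carbon. Going by the values given here, no measured step touches this part of the molecule, so the ester step gives no guidance on its size or direction; it only shows that the core tolerates a change elsewhere without effect. The five-membered ring is removed and the acetamido group enters in its place, and the expectation for compound 3 in this assay is a weaker result, estimated at 8000 nM, with a range from 1500 nM to 40000 nM, which corresponds to an expected step of a 4.6-fold higher number from compound 2 to compound 3 (0.67 log units; beyond the scatter).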

Compound 3, half-maximal inhibitory concentration: > 10000 nM
Compound 3 was reported as a limit; the forecaster's own chance of this, stated with the estimate: 25%; middle value at least 1.2-fold (0.09 log units) away from the limit.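

The ester step left compounds within the scatter of each other, whereas the change on the saturated chain carbon bound to a double-bonded chain carbon does not: in this assay the acetamido group in place of the five-membered ring gives an at least 5.7-fold higher number from compound 2 to compound 3 (0.76 log units; beyond the scatter). Compound 3 is reported as a limit and not as a number: the limit of > 10000 nM in this assay, at which 1 of the 3 values shown sits.

This chain position is therefore the first place in the compounds shown where a single change separates two compounds in this read-out, and the acetamido group does not hold the level of compound 2, so the size of the step has a lower bound only.

For the compounds shown here, the single pair cannot say which part of the exchange matters, as the ring, the double bonds outside aromatic rings and the heavy-atom count all change together with the hydrogen-bond donors and acceptors. Also open, from the compounds shown here alone, is how an amine, a carboxylic acid or a longer chain on that same saturated chain carbon would read in this assay, and whether the cyclohexylmethyl ester would behave like the isopropyl ester once the five-membered ring is gone.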